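Dimethylphenyl placement on the carbonyl aryl of the stilbene-chalcone series

The compounds below may be only part of what the source reports. "The series", "measured", "known", "first", "only" and "open" are said of these compounds alone.

Measured so far:
compound 1, `CCCCOc1ccc(C(=O)/C=C/c2c(/C=C/c3ccc(OC)cc3)cc(OC)cc2OC)cc1`: 12.9 ug/mL
compound 2, `COc1ccc(/C=C/c2cc(OC)cc(OC)c2/C=C/C(=O)c2ccccc2C)cc1`: 5.3 ug/mL
compound 3, `COc1ccc(/C=C/c2cc(OC)cc(OC)c2/C=C/C(=O)c2ccc(C)c(C)c2)cc1`: 0.2 ug/mL

In a functional assay on HepG2 cells (Homo sapiens) for antiproliferative activity, read by MTT assay, with a stated time of 48 h (a higher number here means a weaker inhibitor, a lower number a stronger inhibitor), compound 3 gives the lowest number of the three, with a 27-fold lower number from compound 2 to compound 3 (1.42 log units; beyond the scatter) and a 65-fold lower number from compound 1 to compound 3 (1.81 log units; beyond the scatter) both beyond the scatter. Compound 4, `COc1ccc(/C=C/c2cc(OC)cc(OC)c2/C=C/C(=O)c2ccc(C)cc2C)cc1`, differs from compound 3 in one place: 2,4-dimethylphenyl in place of 3,4-dimethylphenyl on a carbonyl carbon. Every step measured so far changes this same aryl on the carbonyl carbon, so all three bear on it. a 2.4-fold lower number from compound 1 to compound 2 (0.39 log units; beyond the scatter) was modest, whereas the two steps into the 3,4-dimethylphenyl were large. The entering 2,4-dimethylphenyl shares one methyl name with the 2-methylphenyl of compound 2 and one with the 3,4-dimethylphenyl of compound 3, so a higher number than compound 3, short of the value of compound 2, is expected. Compound 4 is therefore estimated at 2 ug/mL (range 0.5 ug/mL to 8 ug/mL), an expected step of a 10-fold higher number from compound 3 to compound 4 (1.00 log units; beyond the scatter).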

Compound 4, half-maximal inhibitory concentration: 0.9 ug/mL
For compound 4 the middle estimate is 2.2-fold (0.35 log units) above the measured one, within the range that was stated.
By their numbers in this assay, from the lowest: compound 3; then compound 4; then compound 2; then compound 1.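

In this assay, with the same atoms on the carbonyl carbon, relocating one methyl weakens the compound (a 4.5-fold higher number from compound 3 to compound 4 (0.65 log units; beyond the scatter)), so the methyl pattern on this aryl matters, not the methyl count alone. Adding the second methyl to the 2-methylphenyl still gives a gain (a 5.9-fold lower number from compound 2 to compound 4 (0.77 log units; beyond the scatter)). The 2,4-dimethylphenyl also keeps a large advantage over the 4-butoxyphenyl (a 14-fold lower number from compound 1 to compound 4 (1.16 log units; beyond the scatter)).

Open, going by these compounds, is whether an amine or a carboxylic acid on this aryl would keep such values. Nothing available accounts for the gap between the two dimethylphenyl patterns.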